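A few compounds are considered here, and "the series" means these few. Any claim that something is new, unique, unknown or untested is made for them only; others in the source may bear on it.

In a physicochemical assay for solubility, measured as kinetic solubility (on this read-out lower numbers stand for lower solubility and higher numbers for higher solubility), compound 1 `CNC(=O)c1cc(C(=O)N[C@H]2CC[C@H](O)CC2)n([C@@H](C)c2cccc(Cl)c2)n1` gives >= 143 ug/mL, which is a limit and not an exact number. Compound 2 `CNC(=O)c1cc(C(=O)N[C@H]2CC[C@H](O)CC2)c([C@@H](C)c2cccc(Cl)c2)o1` gives >= 179 ug/mL, also a limit. Compound 3 `CNC(=O)c1cc(C(=O)N[C@H]2[C@@H]3C[C@H](O)C[C@@H]32)n([C@@H](C)c2cccc(Cl)c2)n1` gives >= 168 ug/mL, again a limit. Compound 4 `CNC(=O)c1cc(C(=O)N[C@H]2CC[C@H](O)CC2)n([C@@H](C)c2ccc(C(F)(F)F)cc2)n1` changes one group of compound 1: 4-(trifluoromethyl)phenyl in place of 3-chlorophenyl on a saturated chain carbon bound to an aromatic nitrogen and a saturated chain carbon. Going by the values given here, the only measured step, a step that the two limits leave unreadable from compound 1 to compound 3, concerns the group on an amide-type nitrogen, and its size cannot be read, so no measured step bears on this change. The entering group has more heavy atoms and, like the leaving group, no hydrogen-bond donors or acceptors, so a modest fall is tentatively expected: an at least 1.3-fold lower number from compound 1 to compound 4 (0.11 log units; that floor lies within the scatter). The estimate for compound 4 is 110 ug/mL, with an expected range of 35 ug/mL to 190 ug/mL.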

Compound 4, solubility: >= 175 ug/mL
Compound 4: no number, only a limit; the forecaster's own chance of this, stated with the estimate: 40%; middle value at least 1.5-fold (0.20 log units) away from the limit.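

Compound 1 and compound 4 both give only limits in this assay, and the step between them cannot be read. On these data alone, whether 4-(trifluoromethyl)phenyl or 3-chlorophenyl gives the higher number remains open.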